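The compounds below may be only part of what the source reports. "The series", "measured", "known", "first", "only" and "open" are said of these compounds alone.

Measured so far:
compound 1 `CCCCCCCCC1CC1CCCCCCCC(=O)OC[C@H](CO[C@@H]1O[C@H](CO)[C@@H](O)[C@H](O)[C@H]1O)OC(=O)CCCCCCCC1CC1CCCCCCCC` gives 120000 nM
compound 2 `CCCCCCCCCCCC(=O)OC[C@H](CO[C@@H]1O[C@H](CO)[C@@H](O)[C@H](O)[C@H]1O)OC(=O)CCCCCCCCCCC` gives 96100 nM

For the measured compounds named here, in an ADME assay on HUVEC cells (Homo sapiens) for cytotoxicity, read by MTT assay (on this read-out lower numbers stand for stronger inhibition and higher numbers for weaker inhibition), compound 1 gives 120000 nM and compound 2 gives 96100 nM, so compound 1 stands within the scatter of the only other number available. Compound 3 `CCCCCCCC/C=C\CCCCCCCC(=O)O[C@H](COC(=O)CCCCCCCC1CC1CCCCCCCC)CO[C@@H]1O[C@H](CO)[C@@H](O)[C@H](O)[C@H]1O` is not yet measured. It keeps the core of compound 1 and one of its two chains, and on the other chain it carries dec-1-en-1-yl in place of 2-octylcyclopropyl on a saturated chain carbon, seven bonds along the chain from a carbonyl carbon. Going by the values given here, no measured pair shows this change on its own, so the expectation rests only on how close the two values are. In this assay no step beyond the scatter is expected. The expected step is a 1.1-fold lower number from compound 1 to compound 3 (0.04 log units; within the scatter), which would stay within the scatter. For compound 3 the estimated value is 110000 nM, with an expected range from 60000 nM to 200000 nM.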

Compound 3, half-maximal inhibitory concentration: 99800 nM
For compound 3 the middle estimate is 1.1-fold (0.04 log units) above the measured one, and the stated range covers the measured number.
By their numbers in this assay, from the lowest: compounds 2, 3 and 1 (each within the scatter of the next).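

In this assay, replacing 2-octylcyclopropyl with dec-1-en-1-yl on a saturated chain carbon, seven bonds along the chain from a carbonyl carbon, gives a step that can be read on its own (a 1.2-fold lower number from compound 1 to compound 3 (0.08 log units; within the scatter)). For the compounds shown here, this is the first pair in the set to differ in one place, and it shows that on this one chain, a three-membered carbon ring can give way to a double bond with no step beyond the scatter. No supporting measurement bears on this result, so it stands without an explanation.

As far as these compounds go, it remains open whether the same exchange on the other chain, or on both chains together, would also stay within the scatter. Also open, from the compounds shown here alone, is how a carboxylic acid, an amine or a longer chain at this place would read.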